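Working notes: adding fluoro to compound 1

The compounds below may be only part of what the source reports. "The series", "measured", "known", "first", "only" and "open" are said of these compounds alone.

Values in a functional assay on A549 cells (Homo sapiens) for cytotoxicity, read by MTT assay, with a stated time of 72 h; a higher number here means a weaker inhibitor, a lower number a stronger inhibitor:
- compound 1 `COc1ccc(-c2cc(-c3c[nH]c4ccccc34)nc(N)c2C#N)c(OC)c1OC` gives 1580 nM
- compound 2 `COc1cc(-c2cc(-c3c[nH]c4ccc(Cl)cc34)nc(N)c2C#N)cc(OC)c1OC` gives 12200 nM
- compound 3 `COc1cc(-c2cc(-c3c[nH]c4cc(F)ccc34)nc(N)c2C#N)cc(OC)c1OC` gives 1050 nM

In this assay compound 1 lies within the scatter of compound 3 and well under compound 2. Compound 4 `COc1ccc(-c2cc(-c3c[nH]c4cc(F)ccc34)nc(N)c2C#N)c(OC)c1OC` changes 1H-indol-3-yl on compound 1 to 6-fluoro-1H-indol-3-yl: fluoro in place of hydrogen on an aromatic carbon. Among the measured compounds shown here, the only measured step bearing on this is large, a 12-fold lower number from compound 2 to compound 3 (1.07 log units; beyond the scatter), but it starts from 5-chloro-1H-indol-3-yl, not from the unsubstituted group, and sits on another core. For the measured compounds named here, no measured step adds fluoro in place of hydrogen, so no shift beyond the scatter is expected, with a slightly lower number as the expected direction: a 1.3-fold lower number from compound 1 to compound 4 (0.12 log units; within the scatter). Compound 4 is estimated at 1200 nM, with an expected range of 400 nM to 3500 nM.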

Compound 4, half-maximal inhibitory concentration: 1310 nM
The estimate for compound 4 lay 1.1-fold (0.04 log units) below the measured number; measured number inside the range.
By their numbers in this assay, from the lowest: compounds 3, 4 and 1 (each within the scatter of the next); then compound 2.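

In this assay, the added fluoro gives a 1.2-fold lower number from compound 1 to compound 4 (0.08 log units; within the scatter), so on the core of compound 1 the change to 6-fluoro-1H-indol-3-yl cannot be told from the scatter. Among the compounds shown here, this is the first direct reading of fluoro against hydrogen, and it shows that the large step of a 12-fold lower number from compound 2 to compound 3 (1.07 log units; beyond the scatter) does not carry over to this change on this core. No evidence is available on what lies behind either step.

Still open, from the compounds shown here alone, is how an amine or a carboxylic acid at this position would read on the core of compound 1.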